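The compounds below may be only part of what the source reports. "The series", "measured", "known", "first", "only" and "open" are said of these compounds alone.

Measured compounds:
compound 1 `O=C(N[C@H]1CC[C@H](O)CC1)c1noc(-c2ccc(C(F)(F)F)cc2)c1Cl` — 392 nM
compound 2 `O=C(NC1CCCC1)c1noc(-c2ccc(Br)cc2)c1Br` — 410 nM

In a functional assay on CHO cells for antagonist activity at transient receptor potential cation channel subfamily V member 1 (Homo sapiens), read by fluorescence and calcium flux (a lower number here means a stronger inhibitor, a higher number a weaker inhibitor), compound 1 gives 392 nM and compound 2 gives 410 nM. For the measured compounds named here, on these two numbers compound 2 stands alongside compound 1: the gap between them lies within the usual scatter, so the two read as equivalent, and no ordering of the pair is supported.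

Compound 3 `O=C(NC1CCCC1)c1noc(-c2ccccc2Cl)c1Br` has not been measured. Relative to compound 2 the change is 2-chlorophenyl in place of 4-bromophenyl on an aromatic carbon; the rest of the molecule is unchanged. Going by the values given here, no measured pair in the set isolates this change, so the size of the step rests on expectation alone. The expectation is a step beyond the scatter towards a higher number in this assay, that is, weaker inhibition, though a result within the scatter of compound 2 is not excluded. Compound 3 is expected at 1200 nM, with a range from 400 nM to 4000 nM. The expected step is a 2.9-fold higher number from compound 2 to compound 3 (0.47 log units; beyond the scatter).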

Compound 3, half-maximal inhibitory concentration: "not active" (no number reported)
Nothing numeric was reported for compound 3; no gap can be computed for the estimate.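

For the compounds shown here, compound 3 is reported as "not active" in this assay with no number, so no step from compound 2 to compound 3 can be read. Nothing available bears on this result. The compounds shown leave open how much 2-chlorophenyl in place of 4-bromophenyl weakens inhibition, and whether the halogen or its ring position matters.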